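Chloro for Methoxy on the Unsaturated Linker

A few compounds are considered here, and "the series" means these few. Any claim that something is new, unique, unknown or untested is made for them only; others in the source may bear on it.

Compound 1 `COc1cccc(/C=C/C(=O)Nc2nc3ccccc3c(=O)s2)c1`: in an assay on CHO cells for displacement of a labelled ligand from adenosine receptor A3 (Homo sapiens), read by scintillation counting, with a stated time of 60 min (a higher number here means a weaker inhibitor, a lower number a stronger inhibitor), compound 1 gives > 1000 nM, which is a limit of the assay.
Compound 2 `COc1cccc(CCCC(=O)Nc2nc3ccccc3c(=O)s2)c1`: in this assay compound 2 gives 382 nM.
Compound 3 `O=C(CCCc1cccc(Cl)c1)Nc1nc2ccccc2c(=O)s1`: in this assay compound 3 gives > 1000 nM, which is a limit of the assay.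

Compound 1 and compound 2 carry the same core with different linkers; the difference between the two cores is not broken down here. Compound 4 `O=C(/C=C/c1cccc(Cl)c1)Nc1nc2ccccc2c(=O)s1` has not yet been measured. It differs from compound 1 by chloro in place of methoxy on an aromatic carbon. The same change, (chloro in place of methoxy on an aromatic carbon), was already made from compound 2 to compound 3 and gave an at least 2.6-fold higher number from compound 2 to compound 3 (0.41 log units; beyond the scatter). Because the limit of > 1000 nM in this assay, at which 2 of the 3 values shown sit, already holds compound 1, the same change is expected to leave compound 4 at that limit or beyond it. The expected step, a step that the limit leaves unreadable from compound 1 to compound 4, is estimated to match the earlier one in direction. Compound 4 is therefore expected to give about 3000 nM, estimated between 1000 nM and 15000 nM.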

Compound 4, inhibition constant: > 1000 nM
Compound 4: no number, only a limit (the forecaster's own chance of this, stated with the estimate: 90%); the middle value is on the limit's open side.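

No step from compound 1 to compound 4 can be read in this assay, where both compounds give only a limit: the limit of > 1000 nM in this assay, at which 3 of the 4 values shown sit.

On these data alone, whether chloro in place of methoxy changes the number on the unsaturated linker stays open.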